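A few compounds are considered here, and "the series" means these few. Any claim that something is new, unique, unknown or untested is made for them only; others in the source may bear on it.

Measured so far, in a functional assay on HeLa cells (Homo sapiens) for antiproliferative activity, read by MTT assay, with a stated time of 96 h; on this read-out lower numbers stand for stronger inhibition and higher numbers for weaker inhibition:
compound 1, `O=C1C2=C(C(=O)c3ncccc31)C1(CS2)NC(=O)N(c2ccc([N+](=O)[O-])cc2)C1=O`, gives 100 nM
compound 2, `Cc1ccc(N2NC(=O)NC3(CSC4=C3C(=O)c3ncccc3C4=O)C2=O)cc1`, gives 210 nM
compound 3, `O=C1NN(c2ccc(Cl)cc2)C(=O)C2(CSC3=C2C(=O)c2ncccc2C3=O)N1`, gives 150 nM

Compound 1 holds the lowest of the three numbers. Compound 3 sits closest to it, within the scatter of this assay, while compound 2 lies beyond the scatter on the higher side. Compound 4, `CCCCc1ccc(N2C(=O)NC3(CSC4=C3C(=O)c3ncccc3C4=O)C2=O)cc1`, has not yet been measured. It differs from compound 1 in one place: butyl in place of nitro on an aromatic carbon.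

For the measured compounds named here, only one measured step bears on this change, and only loosely, since it also swaps one group for another on the same kind of aromatic carbon: a 1.4-fold lower number from compound 2 to compound 3 (0.15 log units; within the scatter). That step stayed within the scatter, which hints that a swap of the group on this phenyl ring may move the number little. Going by the values given here, the swap here is larger, though, and no measured pair shows nitro against butyl directly, so the expectation rests on thin ground. Compound 4 is therefore expected to land close to compound 1, with a wide range: the estimated step is a 1.8-fold higher number from compound 1 to compound 4 (0.26 log units; within the scatter). The estimate for compound 4 is 180 nM, between 70 nM and 450 nM.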

Compound 4, half-maximal inhibitory concentration: 90 nM
The estimate for compound 4 lay 2.0-fold (0.30 log units) above the measured number; low and high end bracket the measured number.
By their numbers in this assay, from the lowest: compounds 4, 1, 3 and 2 (each within the scatter of the next, the first and the last beyond it).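

In this assay, a 1.1-fold lower number from compound 1 to compound 4 (0.05 log units; within the scatter), so on the core of compound 1 the two numbers cannot be told apart. For the compounds shown here, this is the first pair that tests a change on the phenyl ring of this core, since the earlier methyl and chloro pair sits on a different core, and the two groups here have little in common by simple count: nitro brings nitrogen, oxygen and hydrogen-bond acceptors, whereas butyl is carbon only and has no acceptors, yet the read-out does not separate them. Nothing available explains why such different groups give matching numbers, so this stands as an observation only.

On these data alone, what an amine, a carboxylic acid or a longer chain would give at this place remains open, as does a phenyl ring with only hydrogen there. Also open, as far as these compounds go, is whether butyl and nitro would match on the core shared by compound 2 and compound 3, and a single pair sets no general pattern for this position.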